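Aryl sulfonate series: amide to urea at compound 3

The compounds below may be only part of what the source reports. "The series", "measured", "known", "first", "only" and "open" are said of these compounds alone.

Compound 3 `CC(C)(C)C(=O)Nc1ccc(S(=O)(=O)Oc2ccccc2I)cc1` gives the lowest of three numbers in a functional assay on HT-29 cells (Homo sapiens) for antiproliferative activity, read by sulforhodamine B assay, with a stated time of 48 h (a lower number here means a stronger inhibitor, a higher number a weaker inhibitor), 9500 nM, though the two other compounds lie within the scatter of it: compound 1 `CC(C)C(=O)Nc1ccc(S(=O)(=O)Oc2ccccc2C(C)C)cc1` gives 14000 nM and compound 2 `CC(C)c1ccccc1OS(=O)(=O)c1ccc(NC(=O)C(C)(C)C)cc1` gives 15000 nM. Compound 4 `CCNC(=O)Nc1ccc(S(=O)(=O)Oc2ccccc2I)cc1` differs from compound 3 by ethylamino in place of tert-butyl on a carbonyl carbon. The measured step that touches the same region, on the carbonyl substituent, is a 1.1-fold higher number from compound 1 to compound 2 (0.03 log units; within the scatter), within the scatter. The other step, a 1.6-fold lower number from compound 2 to compound 3 (0.20 log units; within the scatter), alters a different part and is also within the scatter. No step beyond the scatter is therefore expected in this assay from compound 3 to compound 4. Compound 4 is expected to give 9500 nM, with a range of 3000 nM to 30000 nM. The expected step is no change at the digits printed from compound 3 to compound 4 (within the scatter).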

Compound 4, half-maximal inhibitory concentration: 5300 nM
Compound 4: the middle estimate sits 1.8-fold (0.25 log units) above what was measured; the measured number falls inside the stated range.
By their numbers in this assay, from the lowest: compounds 4, 3, 1 and 2 (each within the scatter of the next, the first and the last beyond it).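

Among the compounds shown here, compound 4 puts a nitrogen-linked group on the carbonyl carbon, where the earlier compounds carry only carbon-linked groups, and ethylamino in place of tert-butyl gives a 1.8-fold lower number from compound 3 to compound 4 (0.25 log units; within the scatter) in this assay. The urea with its added hydrogen-bond donor therefore stays within the scatter of the amide with the iodo group held fixed. Nothing available explains this result. Still open, as far as these compounds go, is whether dimethylamino or butylamino on the carbonyl carbon would hold this level. Also open, from the compounds shown here alone, is whether ethylamino behaves the same with isopropyl in place of iodo on the aromatic carbon.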